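From a hydroxyphenyl arm to a thiophene arm

A few compounds are considered here, and "the series" means these few. Any claim that something is new, unique, unknown or untested is made for them only; others in the source may bear on it.

Compound 1, `CC1=CC[C@H](C(C)(C)NC(=S)NN)CC1`, gives > 100000 nM in a functional assay on OVCAR-3 cells (Homo sapiens) for inhibition, read by sulforhodamine B assay, with a stated time of 48 h; a higher number here means a weaker inhibitor of growth, a lower number a stronger inhibitor of growth; this is a limit of the assay rather than a number.
Compound 2, `CC1=CC[C@H](C(C)(C)NC(=S)N/N=C/c2ccccc2O)CC1`, gives 11800 nM in this assay.
Compound 3, `CC1=CC[C@H](C(C)(C)NC(=S)N/N=C/c2ccccc2[N+](=O)[O-])CC1`, gives 25800 nM in this assay.

Compound 2 holds the lowest of the two numbers given. Its nearest neighbour is compound 3, reached by a 2.2-fold higher number from compound 2 to compound 3 (0.34 log units; beyond the scatter). Compound 1 sits at a limit, (the limit of > 100000 nM in this assay, at which 1 of the 3 values shown sits), so it offers no number to compare.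

The unmeasured compound 4, `CC1=CC[C@H](C(C)(C)NC(=S)N/N=C/c2cccs2)CC1`, differs from compound 2 in one place: thiophen-2-yl in place of 2-hydroxyphenyl on a carbon with a double bond to nitrogen. Among the measured compounds shown here, no measured step exchanges the ring itself. For the measured compounds named here, the only measured step that changes the group on the carbon double-bonded to nitrogen is the modest one from compound 2 to compound 3, a 2.2-fold higher number from compound 2 to compound 3 (0.34 log units; beyond the scatter), which swapped one substituent on the same benzene ring. That single step suggests that changes at this position shift the number only modestly in this assay, and the direction for a new ring cannot be read from it.

For compound 4 the expected result in this assay is 20000 nM, within a range from 7000 nM to 60000 nM. That estimate means a 1.7-fold higher number from compound 2 to compound 4 (0.23 log units; within the scatter), a step expected to be small and possibly within the scatter.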

Compound 4, concentration for total growth inhibition: 35100 nM
For compound 4 the middle estimate is 1.8-fold (0.24 log units) below the measured one, within the range that was stated.
By their numbers in this assay, from the lowest: compound 2; then compounds 3 and 4 (each within the scatter of the next). At a limit, above all of these: compound 1.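

Among the compounds shown here, the new result is the first at this position in which the ring itself changes, and in this assay the change remains modest, with a 3.0-fold higher number from compound 2 to compound 4 (0.47 log units; beyond the scatter). Compound 3 and compound 4 lie within the scatter of each other, so swapping the benzene ring for thiophen-2-yl and swapping the hydroxy for a nitro on that benzene ring leave these two compounds indistinguishable, while compound 2 keeps the lowest number, beyond the scatter of both. Even so, the arm of compound 4 counts for something against the bare end of compound 1, with an at least 2.8-fold lower number from compound 1 to compound 4 (0.45 log units; beyond the scatter), and this step gives only a bound, as compound 1 sits at a limit: the limit of > 100000 nM in this assay, at which 1 of the 4 values shown sits.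

The compounds shown cannot separate the loss of the hydroxy group from the change of ring, so why compound 4 gives a higher number than compound 2 stays unexplained. A plain phenyl arm would help to pull these two changes apart, and a furan ring or an amine in place of the hydroxy on the benzene ring would show how far this position tolerates other groups.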